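This account rests on a few compounds, and the source may have more. Where it says the series, first, only, none or still open, it means among the compounds named here.

In a functional assay, with stated times of 30 s and 6 min, in the presence of a further agent that is not named here (on this read-out lower numbers stand for stronger inhibition and higher numbers for weaker inhibition), two compounds sharing one core have been measured so far. Compound 1 `CCOc1cc(OC)c(Br)cc1C(C)=O` gives 37900000 nM, and compound 2 `CCCCCCOc1cc(OC)c(Br)cc1C(C)=O` gives 34000000 nM. For the measured compounds named here, these two values lie within the usual scatter of each other, so compound 2 cannot be separated from its only neighbour on the scale. The next compound, compound 3 `CCCCCCCCCCCCCCOc1cc(OC)c(Br)cc1C(C)=O`, extends the chain further: octyl in place of hydrogen on a saturated chain carbon, six bonds along the chain from an oxygen on an aromatic ring. Going by the values given here, only one measured step bears on this change, the earlier chain extension a 1.1-fold lower number from compound 1 to compound 2 (0.05 log units; within the scatter). That step stayed within the scatter, although a single step is thin evidence for a much larger addition. No step beyond the scatter is therefore expected in this assay. The estimated step is a 1.1-fold lower number from compound 2 to compound 3 (0.05 log units; within the scatter). The estimate for compound 3 is 30000000 nM, with an expected range from 12000000 nM to 60000000 nM.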

Compound 3, half-maximal inhibitory concentration: 6800000 nM
Estimate against measurement, compound 3: 4.4-fold (0.64 log units) above, and the stated range ends above it.
By their numbers in this assay, from the lowest: compound 3; then compounds 2 and 1 (each within the scatter of the next).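

In this assay, the octyl addition at this position, on a saturated chain carbon six bonds along the chain from an oxygen on an aromatic ring, gives a 5.0-fold lower number from compound 2 to compound 3 (0.70 log units; beyond the scatter) and so moves the number beyond the scatter. The earlier extension, a 1.1-fold lower number from compound 1 to compound 2 (0.05 log units; within the scatter) and within the scatter, gave no such sign, so this chain position can affect inhibition, but the effect appears here only with the larger addition, and the step is modest. Nothing at hand explains this step.

The compounds shown do not reveal whether a chain of intermediate length would already produce this step, or whether a still longer chain would lower the number further. They also leave open whether a chain ending in an amine or a carboxylic acid would behave in the same way.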